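The source may hold more compounds than are shown below. What is called first, only, known or untested is meant among the compounds shown, and "the series" means these compounds.

Measured in an ADME assay on KB cells (Homo sapiens) for cytotoxicity, with a stated time of 48 h; a lower number here means a stronger inhibitor, a higher number a weaker inhibitor:
- compound 1 `C=C1[C@H](C)CCC[C@]1(C)CC/C(C)=C/CC1=C(O)C(=O)C=C(N[C@@H](C(=O)O)C(C)C)C1=O`: 6.2 ug/mL
- compound 2 `CC1=CCC[C@](C)(CC/C(C)=C/CC2=C(O)C(=O)C=C(N[C@@H](C(=O)O)[C@@H](C)O)C2=O)[C@@H]1C`: > 10 ug/mL, a limit
- compound 3 `C=C1[C@H](C)CCC[C@]1(C)CC/C(C)=C/CC1=C(O)C(=O)C=C(N[C@H](CO)C(=O)O)C1=O`: > 10 ug/mL, a limit

Compound 3 has no number of its own in this assay. Its reading of > 10 ug/mL is a limit of the assay. The same holds for compound 2, so the picture so far is the limit of > 10 ug/mL in this assay, at which 2 of the 3 values shown sit. Only compound 1 gives a number, at 6.2 ug/mL.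

Compound 4 `C=C1[C@H](C)CCC[C@]1(C)CC/C(C)=C/CC1=C(O)C(=O)C=C(NCC(=O)O)C1=O` has yet to be measured. Its difference from compound 3 is hydrogen in place of hydroxymethyl on a saturated chain carbon bound to an amine nitrogen and a carbonyl carbon. Within the data shown here, one measured step bears on this place, namely an at least 1.6-fold higher number from compound 1 to compound 3 (0.20 log units; that floor lies within the scatter). That step put hydroxymethyl in place of isopropyl, and its floor lies within the scatter, so it fixes no firm size. Among the measured compounds shown here, no measured compound carries hydrogen at this place.

Given the step of an at least 1.6-fold higher number from compound 1 to compound 3 (0.20 log units; that floor lies within the scatter), no change beyond the scatter is expected in this assay, and no direction can be favoured. The estimated step is a step that the limit leaves unreadable from compound 3 to compound 4, and another reading that is only a limit would be no surprise. For compound 4 the expected value is 12 ug/mL, with an estimated range of 6 ug/mL to 25 ug/mL.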

Compound 4, half-maximal inhibitory concentration: 4 ug/mL
Compound 4: middle estimate off by 3.0-fold (0.48 log units), on the high side; the whole stated range lies above it.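

In this assay, hydrogen in place of hydroxymethyl on a saturated chain carbon bound to an amine nitrogen and a carbonyl carbon gives the only step at this place that is shown to lie beyond the scatter: an at least 2.5-fold lower number from compound 3 to compound 4 (0.39 log units; beyond the scatter). Its true size remains a floor, because compound 3 has no number of its own and sits at a limit: the limit of > 10 ug/mL in this assay, at which 2 of the 4 values shown sit.

Hydrogen and isopropyl, by contrast, are not separated at this place, with a 1.6-fold lower number from compound 1 to compound 4 (0.19 log units; within the scatter), so of the groups compared with hydrogen here, only hydroxymethyl differs from it beyond the scatter.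

The compounds shown leave open how far the true value of compound 3 lies from the number of compound 4, and so how large the effect of hydroxymethyl at this place really is. They also leave open whether a methyl group, an aminomethyl group or a longer chain on this carbon would read like hydrogen and isopropyl or would instead read like hydroxymethyl.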